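The source may report more compounds than this note shows. Statements on the series, on what has been measured and on what is new or still open speak of the compounds shown alone.

Compound 3 `CCC(/C=C(\COC(=O)c1ccccc1)C(=O)c1ccc(OC)cc1)CC` shares its core with compound 1 `CCC(/C=C(\COC(C)=O)C(=O)c1ccc(OC)cc1)CC` and compound 2 `COc1ccc(C(=O)/C(=C/C2CCCCC2)COC(C)=O)cc1`, all three tested in a functional assay on A549 cells (Homo sapiens) for inhibition, read by XTT assay, with a stated time of 48 h; a lower number here means a stronger inhibitor, a higher number a weaker inhibitor. In this assay compound 3 gives > 100000 nM, which is a limit of the assay and not a number. Compound 1 likewise gives only a limit in this assay, namely > 100000 nM. The cyclohexyl counterpart of compound 1 is compound 2, which gives 90000 nM in this assay. Going by the values given here, that step, an at least 1.1-fold lower number from compound 1 to compound 2 (0.04 log units; that floor lies within the scatter), is the one measured change that bears on compound 4 `COc1ccc(C(=O)/C(=C/C2CCCCC2)COC(=O)c2ccccc2)cc1`, which arises from compound 3 through (cyclohexyl in place of pentan-3-yl on a double-bonded chain carbon bound to a double-bonded chain carbon). The exchange from compound 1 to compound 2 moved the number by no more than the scatter, and the ceiling the limit of > 100000 nM in this assay, at which 2 of the 3 values shown sit, leaves even that move's true size unreadable, just as a step that the two limits leave unreadable from compound 1 to compound 3 is unreadable. The estimated step for compound 4 is a number no higher from compound 3 to compound 4 (the limit leaves the size open), that is, none beyond the scatter. The estimate for compound 4 in this assay is 100000 nM, with a range from 40000 nM to 250000 nM, and a fair chance that the assay again reports only a limit.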

Compound 4, half-maximal inhibitory concentration: 36000 nM
Beside the measured number, compound 4's estimate is 2.8-fold (0.44 log units) above it; measured number below the stated range.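

In this assay, cyclohexyl in place of pentan-3-yl on a double-bonded chain carbon bound to a double-bonded chain carbon now gives a step beyond the scatter, an at least 2.7-fold lower number from compound 3 to compound 4 (0.44 log units; beyond the scatter), which the earlier pair could not show. Going by these compounds alone, with cyclohexyl in place, phenyl in place of methyl on a carbonyl carbon can also be read for the first time, as a 2.5-fold lower number from compound 2 to compound 4 (0.40 log units; beyond the scatter). The cyclohexyl exchange has now been seen on two cores, but its sizes there cannot be compared: the same change on two cores in this assay, an at least 1.1-fold lower number (0.04 log units; that floor lies within the scatter) from compound 1 to compound 2 and an at least 2.7-fold lower number (0.44 log units; beyond the scatter) from compound 3 to compound 4; the limit leaves it open whether they differ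

The step between the two compounds held at the limit cannot be read, and the full size of the steps that start from a limit stays open: the limit of > 100000 nM in this assay, at which 2 of the 4 values shown sit. The compounds shown also do not tell how an amine or a longer chain would fare at this place in this assay.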